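A few compounds are considered here, and "the series" means these few. Any claim that something is new, unique, unknown or untested is made for them only; others in the source may bear on it.

The account begins with compound 1 `CNCC(=O)Nc1cc(OC)ccc1C(=O)c1cc(OC)c(OC)c(OC)c1`, which in a functional assay on MCF7 cells (Homo sapiens) for antiproliferative activity, read by MTT assay, with a stated time of 48 h (a higher number here means a weaker inhibitor, a lower number a stronger inhibitor), gives 550 nM. Compound 2 `CCNCC(=O)Nc1cc(OC)ccc1C(=O)c1cc(OC)c(OC)c(OC)c1` carries a single change from it, (methyl in place of hydrogen on a saturated chain carbon bound to an amine nitrogen), and in this assay compound 2 gives 1050 nM; the step of a 1.9-fold higher number from compound 1 to compound 2 (0.28 log units; within the scatter) lies within the scatter, so the two values show no real difference between them. Compound 3 `C=C(c1ccc2c(c1)C=CC(C)(C)O2)c1ccc(OC)cc1NC(=O)CNC` rests on a different core; how its core differs from that of compound 1 is not broken down here. In this assay compound 3 gives 720 nM, a value within the scatter of both compound 1 and compound 2. Compound 4 `C=C(c1ccc2c(c1)C=CC(C)(C)O2)c1ccc(OC)cc1NC(=O)CNCC` has not yet been measured. It differs from compound 3 by methyl in place of hydrogen on a saturated chain carbon bound to an amine nitrogen, the same change that was made from compound 1 to compound 2, at the same place but on the other core. Because the earlier step of a 1.9-fold higher number from compound 1 to compound 2 (0.28 log units; within the scatter) stayed within the scatter, a step of similar size is expected for compound 4, a 1.5-fold higher number from compound 3 to compound 4 (0.18 log units; within the scatter). For compound 4 the estimated value in this assay is therefore 1100 nM, with a likely range from 500 nM to 2500 nM.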

Compound 4, half-maximal inhibitory concentration: 3370 nM
For compound 4 the middle estimate is 3.1-fold (0.49 log units) below the measured one, outside the stated range (above it).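

In this assay, methyl in place of hydrogen on a saturated chain carbon bound to an amine nitrogen gives a 4.7-fold higher number from compound 3 to compound 4 (0.67 log units; beyond the scatter), a step beyond the scatter, whereas the same change stayed within the scatter on the core of compound 1. Even so, the two steps cannot be told apart: the same change on two cores in this assay, a 1.9-fold higher number (0.28 log units; within the scatter) from compound 1 to compound 2 and a 4.7-fold higher number (0.67 log units; beyond the scatter) from compound 3 to compound 4, 2.5-fold (0.39 log units) apart, within the scatter of two such steps. The series therefore gives no sign that the core alters the effect of this change, but two pairs do not show that the effect is the same on both cores, or that it would hold on any further core.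

The compounds shown leave open how a longer chain such as propyl, a branched chain such as isopropyl, or a dimethylamino group in place of the ethylamino group would behave on either core. They also leave open whether the higher number for compound 4 would continue to rise as the chain on the amine grows.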